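The compounds below may be only part of what the source reports. "The series", "measured", "known", "first", "only" and "open" are said of these compounds alone.

Among the compounds with values here, compound 2 `Cc1cc(C)n2ncc(Br)c2n1` gives the lowest number among the two compounds measured so far in a functional assay on the whole organism with Rattus norvegicus as the target (on this read-out higher numbers stand for an effect only at larger amounts of compound and lower numbers for an effect already at smaller amounts), where compound 2 gives 10 mg/kg. Its nearest neighbour is compound 1 `Cc1cc(C)n2ncc(F)c2n1`, which in this assay gives 40 mg/kg. Within the data shown here, the only measured step that bears on the question is a 4.0-fold lower number from compound 1 to compound 2 (0.60 log units; beyond the scatter), a change that lay beyond the usual scatter of this read-out.

Compound 3 `Cc1cc(C)n2ncc(I)c2n1` is the next member of this series, differing from compound 2 in a single place: iodo in place of bromo on an aromatic carbon. Because the step of a 4.0-fold lower number from compound 1 to compound 2 (0.60 log units; beyond the scatter) moved the number downward when a heavier halogen entered, a further move in the same direction is a reasonable expectation when bromo is in turn exchanged for iodo. Among the measured compounds shown here, no other measured pair speaks to this change, so the size is uncertain, and a plateau cannot be excluded. Compound 3 is therefore expected to give 6 mg/kg in this assay, with a range from 2.5 mg/kg to 20 mg/kg. Relative to its neighbour, the expected step is a 1.7-fold lower number from compound 2 to compound 3 (0.22 log units; within the scatter).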

Compound 3, minimum effective dose: 20 mg/kg
Compound 3: middle estimate off by 3.3-fold (0.52 log units), on the low side; the range from low to high includes it.
By their numbers in this assay, from the lowest: compounds 2, 3 and 1 (each within the scatter of the next, the first and the last beyond it).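

In this assay, the exchange of bromo for iodo on this aromatic carbon gives a 2.0-fold higher number from compound 2 to compound 3 (0.30 log units; within the scatter), so the lowering seen with a 4.0-fold lower number from compound 1 to compound 2 (0.60 log units; beyond the scatter) is not shown to continue when iodo enters, and the read-out does not separate these two halogens at this position. Iodo in place of fluoro gives a 2.0-fold lower number from compound 1 to compound 3 (0.30 log units; within the scatter), which leaves compound 3 within the scatter of both of the other compounds, and only compound 1 and compound 2 remain clearly apart, so the three halogens form no graded series by atom size or weight. Nothing in the data available here accounts for this result.

From the compounds shown here alone, all three compounds carry a halogen at this place, so it remains open what chloro, a plain hydrogen, a methyl group, a nitrile or an amine would give on the same carbon of the five-membered ring. Going by these compounds, the methyl groups of the shared core are also the same throughout, so it remains open whether a longer chain in their place would change the read-out or alter the effect of the halogen exchange.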